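Methylating the hydroxyl on the amine side chain

A few compounds are considered here, and "the series" means these few. Any claim that something is new, unique, unknown or untested is made for them only; others in the source may bear on it.

In a functional assay (Pituitary gland cell) with Rattus norvegicus as the target (on this read-out higher numbers stand for an effect only at larger amounts of compound and lower numbers for an effect already at smaller amounts), compound 3, with the structure `C[C@@H](O)CCNC(C)(C)CC(=O)N[C@@H]1CCc2ccccc2N(Cc2ccc(-c3ccccc3-c3nn[nH]n3)cc2)C1=O`, gives 10 nM. Compound 1, with the structure `CC(C)(O)CNC(C)(C)CC(=O)N[C@@H]1CCc2ccccc2N(Cc2ccc(-c3ccccc3-c3nn[nH]n3)cc2)C1=O`, gives 10 nM, and compound 2, with the structure `CC(C)[C@H](O)CNC(C)(C)CC(=O)N[C@@H]1CCc2ccccc2N(Cc2ccc(-c3ccccc3-c3nn[nH]n3)cc2)C1=O`, gives 1000 nM. Compound 3 thus sits level with compound 1, the two together at the lowest numbers of the three, while compound 2 lies well apart from both.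

Compound 4, with the structure `CO[C@H](C)CNC(C)(C)CC(=O)N[C@@H]1CCc2ccccc2N(Cc2ccc(-c3ccccc3-c3nn[nH]n3)cc2)C1=O`, differs from compound 3 only in the group on the saturated chain carbon bound to the amine nitrogen: 1-methoxyethyl in place of 2-hydroxypropyl on a saturated chain carbon bound to an amine nitrogen. The hydrogen-bond donor of compound 3 is therefore gone, and the oxygen is carried on a different carbon.

Within the data shown here, two measured steps bear on this position. The step of no change at the digits printed from compound 1 to compound 3 (within the scatter) shows that moving the hydroxyl from one carbon to another can leave the number unchanged. The step of a 100-fold higher number from compound 1 to compound 2 (2.00 log units; beyond the scatter) shows that a different rearrangement of the same kind of chain can cost a great deal. Among the measured compounds shown here, none of the measured steps removes the hydroxyl donor, so the change in compound 4 is untested ground. A moderate loss is expected, a 5.0-fold higher number from compound 3 to compound 4 (0.70 log units; beyond the scatter), with wide uncertainty. For compound 4 the expected value in this assay is 50 nM, within a range from 10 nM to 500 nM.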

Compound 4, concentration for half-maximal effect: 20 nM
Beside the measured number, compound 4's estimate is 2.5-fold (0.40 log units) above it; measured number inside the range.
By their numbers in this assay, from the lowest: compounds 1, 3 and 4 (each within the scatter of the next); then compound 2.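

In this assay the change to 1-methoxyethyl from 2-hydroxypropyl gives a 2.0-fold higher number from compound 3 to compound 4 (0.30 log units; within the scatter) and the comparison with the other low compound gives a 2.0-fold higher number from compound 1 to compound 4 (0.30 log units; within the scatter) so on this chain the hydroxyl hydrogen can be lost without a shift that stands clear of the usual scatter. Among these compounds, all the earlier compounds carried a hydroxyl, so none of them could show that a side chain with no hydrogen-bond donor still sits with compound 1 and compound 3, while the step of a 50-fold lower number from compound 2 to compound 4 (1.70 log units; beyond the scatter) leaves compound 2 alone at the high end of the series. No measurement shown here gives a reason for this tolerance or for the high number of compound 2.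

The compounds shown leave open whether the oxygen itself is needed on this chain, which a plain alkyl chain such as butyl, or an amine or a carboxylic acid in its place, would test. They also leave open how the number responds to a larger ether such as ethoxy or to the opposite configuration at the methoxy-bearing carbon.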